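The source may hold more compounds than are shown below. What is called first, only, known or untested is meant among the compounds shown, and "the series" means these compounds.

Measured compounds:
- compound 1, `CCCNC(=O)c1ccc(CN(C)C(=O)c2cc(C(C)C)c(O)cc2O)cc1`: 420 nM
- compound 2, `COc1cc(CN(C)C(=O)c2cc(Cl)c(O)cc2O)cc(OC)c1OC`: 73100 nM
- compound 3, `O=C(NCc1ccccc1)c1cc(Cl)c(O)cc1O`: 86200 nM

The three compounds were tested in a functional assay on NCI-H1975 cells (Homo sapiens) for antiproliferative activity, with a stated time of 72 h; on this read-out higher numbers stand for weaker inhibition of growth and lower numbers for stronger inhibition of growth. Compound 1 gives 420 nM in this assay, a far lower number than the other two. Compound 2 gives 73100 nM, which places it second highest of the three numbers. Its nearest neighbour is compound 3, whose value of 86200 nM lies within the usual scatter of compound 2, so the two cannot be told apart on this read-out. The gap between compound 2 and compound 1 is large and well beyond the scatter.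

The unmeasured compound 4, `COc1cc(CN(C)C(=O)c2cc(Cl)c(O)cc2O)c(Br)c(OC)c1OC`, is built from compound 2 by a single change: bromo in place of hydrogen on an aromatic carbon. Among the compounds with values here, no pair of measured compounds shows what such a change does, so there is nothing to lean on beyond the value of compound 2 itself.

With no guide from the measured pairs, the expected step from compound 2 to compound 4 is taken as small, likely none beyond the scatter, that is a 1.2-fold lower number from compound 2 to compound 4 (0.09 log units; within the scatter). Compound 4 is therefore expected to give about 60000 nM in this assay, with a range from 20000 nM to 160000 nM.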

Compound 4, concentration for 50% growth inhibition: 34300 nM
Beside the measured number, compound 4's estimate is 1.7-fold (0.24 log units) above it, and the stated range covers the measured number.
By their numbers in this assay, from the lowest: compound 1; then compound 4; then compounds 2 and 3 (each within the scatter of the next).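

In this assay, within the data shown here, bromo in place of hydrogen on an aromatic carbon, ortho to a large group and ortho to a methoxy group, gives a 2.1-fold lower number from compound 2 to compound 4 (0.33 log units; beyond the scatter), the first step that can be read from a matched pair. It shows that this carbon accepts one added heavy atom with no loss of growth inhibition, and that the modest step, which lies beyond the usual scatter, runs toward stronger inhibition. No measurement at hand explains why the number falls.

The compounds shown leave open whether this result is particular to bromo, as it is unknown how a fluoro group, a methyl group or an amine on the same carbon would compare. Among these compounds, it also remains open whether the same change would give a similar step on a different parent compound, as this is the only matched pair.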